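Methyl for methoxy: a small change on a shared core

The source may hold more compounds than are shown below. What is called first, only, known or untested is meant among the compounds shown, and "the series" means these compounds.

Of the compounds shown here, two built on the same core have been measured in a functional assay for inhibition, with Homo sapiens as the target; on this read-out higher numbers stand for weaker inhibition and lower numbers for stronger inhibition. Compound 1 `Cc1cccc(Nc2nccc(-c3ccncc3)n2)c1` gives 8800 nM in this assay. Compound 2 `COc1cccc(Nc2nccc(-c3ccco3)n2)c1` gives 400 nM in this assay, the lower of the two numbers and a gap to compound 1 that lies beyond the scatter. Compound 1 and compound 2 differ in two places at once, so no single change can be read from that pair.

Compound 3 `Cc1cccc(Nc2nccc(-c3ccco3)n2)c1` is the not yet measured neighbour of compound 2: the change is methyl in place of methoxy on an aromatic carbon. Among the measured compounds shown here, no measured pair shows this single change. Swapping a methoxy for a methyl here is a small change, so the expected step from compound 2 to compound 3 in this assay is a 2.0-fold higher number from compound 2 to compound 3 (0.30 log units; within the scatter), a slight weakening that may well fall within the scatter. Compound 3 is therefore estimated at 800 nM in this assay, within a range from 250 nM to 2500 nM.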

Compound 3, half-maximal inhibitory concentration: 2100 nM
Beside the measured number, compound 3's estimate is 2.6-fold (0.42 log units) below it; the measured number falls inside the stated range.
By their numbers in this assay, from the lowest: compound 2; then compound 3; then compound 1.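

Swapping methoxy for methyl on this aromatic carbon is a small change, yet it gives a 5.3-fold higher number from compound 2 to compound 3 (0.72 log units; beyond the scatter) in this assay and so has a measurable effect here. Compound 3 also separates out the other difference between the first two compounds: furan-2-yl in place of pyridin-4-yl gives a 4.2-fold lower number from compound 1 to compound 3 (0.62 log units; beyond the scatter). Both single changes therefore contribute to the gap between compound 1 and compound 2. No measurement available here explains why either change moves the number.

Among the compounds shown, this carbon carries only methoxy or methyl, so it remains open what an ethoxy group, a hydroxyl group or an amine would do there. The compounds shown also do not pair methoxy with pyridin-4-yl, so whether the two steps would simply add up on the shared core is unknown.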